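The source may hold more compounds than are shown below. What is called first, only, known or untested is meant among the compounds shown, and "the series" means these compounds.

Going by the values given here, in a functional assay on L1210 cells (Mus musculus) for inhibition (on this read-out higher numbers stand for weaker inhibition and lower numbers for stronger inhibition), compound 1 `O=C1CCCCC/C1=C\c1cccc(F)c1` gives 382000 nM and compound 2 `Cc1cccc(/C=C2\CCCCCC2=O)c1` gives 263000 nM, so compound 2 stands within the scatter of the only other measured compound. Compound 3 `COc1cccc(/C=C2\CCCCCC2=O)c1` differs from compound 2 by methoxy in place of methyl on an aromatic carbon. Among the compounds with values here, only one measured step bears on this change, a swap of methyl for fluoro on an aromatic carbon. Because a 1.5-fold lower number from compound 1 to compound 2 (0.16 log units; within the scatter) stays within the scatter, no step beyond the scatter is expected in this assay. The estimated change is a 1.1-fold higher number from compound 2 to compound 3 (0.06 log units; within the scatter). For compound 3 the expected value is 300000 nM, with an estimated range of 130000 nM to 650000 nM.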

Compound 3, half-maximal inhibitory concentration: 283000 nM
Beside the measured number, compound 3's estimate is 1.1-fold (0.03 log units) above it; the range from low to high includes it.
By their numbers in this assay, from the lowest: compounds 2, 3 and 1 (each within the scatter of the next).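

In this assay the methoxy in place of methyl on this aromatic carbon gives a 1.1-fold higher number from compound 2 to compound 3 (0.03 log units; within the scatter) and the methoxy in place of fluoro gives a 1.3-fold lower number from compound 1 to compound 3 (0.13 log units; within the scatter) so all three groups now lie within the scatter of one another. Adding a hydrogen-bond acceptor and one more heavy atom at this place therefore produces no step that can be told apart from the scatter. No evidence is available that bears on this result. From the compounds shown here alone, whether an amine or a carboxylic acid on this carbon would give a step beyond the scatter remains open.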